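From Benzyloxy to Methyl on a Carbonyl Carbon

The compounds below may be only part of what the source reports. "The series", "measured", "known", "first", "only" and "open" are said of these compounds alone.

Measured in a functional assay on NALM-6 cells (Homo sapiens) for cytotoxicity, with a stated time of 72 h; a lower number here means that less compound is needed, a higher number that more compound is needed for the effect:
- Compound 1 `CCOC(=O)/C=C/c1cc(/C=C/[C@](C)(/C=C/c2ccc(OC)cc2)CCC=C(C)C)ccc1O`: > 43400 nM, a limit
- Compound 2 `COc1ccc(/C=C/[C@@](C)(/C=C/c2ccc(O)c(/C=C/C(=O)OCc3ccccc3)c2)CCC=C(C)C)cc1`: > 43400 nM, a limit

Compound 2 has no exact number, and its value is only a limit. Both measured compounds sit at the limit of > 43400 nM in this assay, at which 2 of the 2 values shown sit. Compound 3 `COc1ccc(/C=C/[C@@](C)(/C=C/c2ccc(O)c(/C=C/C(C)=O)c2)CCC=C(C)C)cc1` carries methyl in place of benzyloxy on a carbonyl carbon. Among the compounds with values here, the only measured step is a step that the two limits leave unreadable from compound 1 to compound 2, so it offers no size to carry over. A modest move to lower numbers in this assay is expected, with low confidence, and another limit remains likely. Compound 3 is estimated at 25000 nM, with an expected range of 7000 nM to 43400 nM. The expected change is an at least 1.7-fold lower number from compound 2 to compound 3 (0.23 log units; that floor lies within the scatter).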

Compound 3, half-maximal effective concentration: > 43400 nM
Compound 3: a limit, no number; the forecaster's own chance of this, stated with the estimate: 55%; middle value at least 1.7-fold (0.23 log units) from the limit.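

Within the data shown here, compound 1, compound 2 and compound 3 all give only a limit in this assay, so no step among them can be read: the limit of > 43400 nM in this assay, at which 3 of the 3 values shown sit. The compounds shown leave open the exact value of each one, and whether changing the group on the carbonyl carbon shifts it at all.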